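Swapping Imidazole for Methylpyrazole on a Shared Core

The source may report more compounds than this note shows. Statements on the series, on what has been measured and on what is new or still open speak of the compounds shown alone.

Three compounds share one core and differ only in the ring attached to it. Compound 1 `c1cnc(-c2ccccc2OCC2=NCCN2)nc1` carries a pyrimidin-2-yl group. In a functional assay for activation of Alpha-1D adrenergic receptor (Homo sapiens), read by calcium flux (on this read-out lower numbers stand for an effect already at smaller amounts and higher numbers for an effect only at larger amounts of compound), compound 1 gives < 100000 nM, which is a limit of the assay and not a number. Compound 2 `c1ccc(-c2ccoc2)c(OCC2=NCCN2)c1` carries a furan-3-yl group, and in this assay compound 2 gives 5.01 nM. Compound 3 `c1ccc(-c2ncc[nH]2)c(OCC2=NCCN2)c1` carries a 1H-imidazol-2-yl group; in this assay compound 3 gives < 100000 nM, again a limit and not a number. Compound 3 therefore stands at the limit, and only compound 2 has a measured number. The steps a step that the two limits leave unreadable from compound 1 to compound 3 and a step that the limit leaves unreadable from compound 2 to compound 3 are both of unreadable size, as the limit of < 100000 nM in this assay, at which 2 of the 3 values shown sit, shows. Compound 4 `Cn1nccc1-c1ccccc1OCC1=NCCN1` is not yet measured; it differs from compound 3 by 1-methyl-1H-pyrazol-5-yl in place of 1H-imidazol-2-yl on an aromatic carbon. Among the measured compounds shown here, no measured step gives a readable size for this change, so direction and size remain open. Compound 2, with its value of 5.01 nM, carries no hydrogen-bond donor on its attached ring, and compound 4 likewise carries none there. On that basis compound 4 is expected to give 50 nM in this assay, within 5 nM to 5000 nM, which would mean an estimated step that the limit leaves unreadable from compound 3 to compound 4.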

Compound 4, half-maximal effective concentration: < 100000 nM
Compound 4: only a limit was reported; the forecaster's own chance of this, stated with the estimate: 30%; the middle value lies beyond the limit too.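

No step from compound 1, compound 2 or compound 3 to compound 4 can be read in this assay, because every such pair includes a value that is only a limit: the limit of < 100000 nM in this assay, at which 3 of the 4 values shown sit.

The compounds shown leave open where the actual values of compound 1, compound 3 and compound 4 lie, and how far each stands from compound 2.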